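A few compounds are considered here, and "the series" means these few. Any claim that something is new, unique, unknown or untested is made for them only; others in the source may bear on it.

Measured compounds:
- compound 1, `S=C(N/N=C/c1ccc(Oc2ccccc2)cc1)Nc1ccc(Br)cc1`, in a physicochemical assay for lipophilicity, in phosphate buffer, measured as octanol-water partition, with a stated time of 24 h (on this read-out lower numbers stand for lower lipophilicity and higher numbers for higher lipophilicity), gives 6.38
- compound 2, `Fc1ccc(Oc2ccc(/C=N/NC(=S)Nc3ccc(Br)cc3)cc2)cc1`, in this assay gives 5.82

Compound 2 holds the lowest of the two numbers seen so far in this assay; its nearest neighbour is compound 1, which sits higher by a step that lies beyond the scatter. Among the compounds with values here, the one measured step, a number 0.56 log units lower from compound 1 to compound 2 (beyond the scatter), was the only change recorded between them.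

Compound 3, `Fc1ccc(NC(=S)N/N=C/c2ccc(Oc3ccc(F)cc3)cc2)cc1`, is not yet measured. It differs from compound 2 by fluoro in place of bromo on an aromatic carbon. Within the data shown here, no measured step covers this exact exchange of bromo for fluoro, so the step from compound 1 to compound 2 is only an indirect guide: it shows that a single-atom change on one of these rings shifted this assay by an amount well beyond the scatter, and in a downward direction. Since compound 3 loses one bromine and gains one fluorine, the expected step is a number 0.62 log units lower from compound 2 to compound 3 (beyond the scatter), downward, and beyond the scatter. The value expected for compound 3 in this assay is 5.2, within a range from 4.6 to 5.8.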

Compound 3, partition coefficient: 5.19
Beside the measured number, compound 3's estimate is 0.01 log units above it; the measured number falls inside the stated range.
By their numbers in this assay, from the lowest: compound 3; then compound 2; then compound 1.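

Putting fluoro in place of bromo on an aromatic carbon, para to a large group, gives a number 0.63 log units lower from compound 2 to compound 3 (beyond the scatter) in this assay and so turns the 4-bromophenyl end of the molecule into a 4-fluorophenyl end. Within the data shown here, the earlier step, a number 0.56 log units lower from compound 1 to compound 2 (beyond the scatter), put fluoro in place of hydrogen at a different place in the molecule, so this result is the first reading for the bromo position itself, and it shows that exchanging one halogen for another here moves the number by more than the usual scatter. Among these compounds, with only this one exchange at the position, the result gives the size and direction of a single change rather than a trend, and no measured evidence is available to explain why the number moved.

The compounds shown leave open how this position would respond to a group of a different kind, such as a methoxy group, an amine or a carboxylic acid, and whether the number would then fall further or rise. They also leave open whether the same exchange of bromo for fluoro would give a step of similar size on a different core.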